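The source may hold more compounds than are shown below. What is called first, only, known or untested is meant among the compounds shown, and "the series" means these compounds.

Measured in a functional assay on MV4-11 cells (Homo sapiens) for antiproliferative activity, read by resazurin assay, with a stated time of 72 h; a higher number here means a weaker inhibitor of growth, a lower number a stronger inhibitor of growth:
- compound 1 `CC(=O)N1CCN(c2ccc(Nc3nccc(-c4c[nH]c5ccccc45)n3)cc2)CC1`: 33 nM
- compound 2 `CC(=O)N1CCCN(c2cccc(Nc3nccc(-c4c[nH]c5ncccc45)n3)c2)CC1`: 20 nM
- compound 3 `CN1CCN(c2cccc(Nc3nccc(-c4cn(C)c5ncccc45)n3)c2)CC1`: 24 nM

Repeated measurements of this kind scatter, and these three numbers lie within that scatter of one another. Compound 2, at 20 nM, therefore cannot be ranked against compound 1 or compound 3.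

Compound 4 `CC(=O)N1CCCN(c2cccc(Nc3nccc(-c4c[nH]c5cccnc45)n3)c2)CC1` has not yet been measured in this assay. It contains the same atoms as compound 2, joined differently: a group of 9 heavy atoms (7 carbon, 2 nitrogen; one five-membered aromatic ring with 1 hetero atom, one six-membered aromatic ring with 1 hetero atom) in place of a group of 9 heavy atoms (7 carbon, 2 nitrogen; one five-membered aromatic ring with 1 hetero atom, one six-membered aromatic ring with 1 hetero atom), on an aromatic carbon. Both groups have a five-membered and a six-membered aromatic ring, but the nitrogen of the six-membered ring sits at a different place.

For the measured compounds named here, no measured pair differs by this change alone, so the data give no direct size for it. The group at this place also differs in compound 1, which gives 33 nM, and in compound 3, which gives 24 nM. Both numbers stay within the scatter of compound 2, so no step beyond the scatter is expected, with a slight lean towards a higher number. The estimate means a 1.8-fold higher number from compound 2 to compound 4 (0.24 log units; within the scatter). For compound 4 the estimated value is 35 nM, with an expected range from 12 nM to 100 nM.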

Compound 4, concentration for 50% growth inhibition: 688 nM
Estimate against measurement, compound 4: 20-fold (1.29 log units) below, and the stated range ends below it.
By their numbers in this assay, from the lowest: compounds 2, 3 and 1 (each within the scatter of the next); then compound 4.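

In this assay, moving one nitrogen to a different place in the six-membered ring of this group gives a 34-fold higher number from compound 2 to compound 4 (1.54 log units; beyond the scatter). The group that leaves and the group that enters have the same atoms, the same counts of hydrogen-bond donors and acceptors and no net charge, so such counts cannot separate them: at this position, activity depends on where the ring nitrogen sits, not only on which atoms are present. The evidence at hand offers no measured explanation for the size of this step.

On these data alone, only these two placements of the ring nitrogen can be compared directly, so it remains open whether the other placements in that ring would resemble compound 2 or compound 4, and whether the same move would cost as much with a different group on the far aniline ring. As far as these compounds go, it is also open whether a fluorine or a methoxy group on the six-membered ring of compound 4 would change its number, or whether a ring with no nitrogen there, on the otherwise unchanged frame of compound 2, would match compound 2.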